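A Fluorine Added to a Benzyl Ether

The source may hold more compounds than are shown below. What is called first, only, known or untested is meant among the compounds shown, and "the series" means these compounds.

Of the compounds shown here, two have so far been measured in an assay on CHO cells for displacement of a labelled ligand from melanin-concentrating hormone receptor 1 (Rattus norvegicus), read by scintillation counting, with a stated time of 1 h; a lower number here means a stronger inhibitor, a higher number a weaker inhibitor. Compound 1 `Cc1c(C2CC2)nc2ccc(NC(=O)COc3ccc(OC(F)(F)F)cc3)cn12` gives 6.3 nM. Compound 2 `Cc1c(C2CC2)nc2ccc(-n3ccc(OCc4ccccc4)cc3=O)cn12`, which shares the same core but carries a different side group, gives 28 nM. Compound 2 therefore stands at the higher of the two numbers, and its gap to compound 1 lies beyond the usual scatter, so of this pair it is the weaker binder.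

Compound 3 `Cc1c(C2CC2)nc2ccc(-n3ccc(OCc4ccc(F)cc4)cc3=O)cn12` has not yet been measured. It differs from compound 2 in one place: fluoro in place of hydrogen on an aromatic carbon. Among the compounds with values here, no pair of measured compounds shows this same change, so there is no direct precedent for its effect. The step of a 1.3-fold lower number from compound 2 to compound 3 (0.10 log units; within the scatter) is expected to stay within the scatter, with no clear direction. Compound 3 is estimated to give 22 nM in this assay, with a plausible range from 8 nM to 60 nM.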

Compound 3, half-maximal inhibitory concentration: 28 nM
The estimate for compound 3 lay 1.3-fold (0.10 log units) below the measured number; measured number inside the range.
By their numbers in this assay, from the lowest: compound 1; then compounds 2 and 3 (each within the scatter of the next).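

In this assay, putting fluoro in place of hydrogen on an aromatic carbon of the benzyl ring, para to a large group, gives no change at the digits printed from compound 2 to compound 3 (within the scatter). Within the data shown here, this is the first pair to isolate this change, and it shows that this carbon of the ring can carry a fluorine without any shift in the number beyond the usual scatter, so benzyloxy and (4-fluorobenzyl)oxy cannot be told apart here. Nothing available explains why the number holds steady at this position.

From the compounds shown here alone, a single fluorine is only one small test of this carbon, so it remains open whether chlorine, a methoxy group or an amine placed there would also leave the number in place. Going by these compounds, the effect of fluoro on the other carbons of this ring also remains open.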